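This account rests on a few compounds, and the source may have more. Where it says the series, first, only, none or still open, it means among the compounds named here.

Compounds measured in an assay on membranes from liver for displacement of a labelled ligand from Sigma intracellular receptor 2 (Rattus norvegicus), read by scintillation counting, with a stated time of 120 min; a lower number here means a stronger inhibitor, a higher number a weaker inhibitor:
- compound 1 `Cc1cccc2sc(NC(=O)CCN3CCN(C(C)(C)C)CC3)nc12`: 200 nM
- compound 2 `Cc1cccc2sc(NC(=O)CCN3CCN(CCN(C)C)CC3)nc12`: > 1000 nM
- compound 3 `Cc1cccc2sc(NC(=O)CCN3CCN(CCN(C(C)C)C(C)C)CC3)nc12`: 121 nM

Of these, the value of compound 2 is a limit of this assay and not a number, as told by the limit of > 1000 nM in this assay, at which 1 of the 3 values shown sits. Compound 3 and compound 1 sit within the scatter of each other, the step being a 1.7-fold lower number from compound 1 to compound 3 (0.22 log units; within the scatter), so neither can be called the stronger of the two. The step of an at least 5.0-fold higher number from compound 1 to compound 2 (0.69 log units; beyond the scatter) and the step of an at least 8.2-fold lower number from compound 2 to compound 3 (0.91 log units; beyond the scatter) show that the substituent on the amine nitrogen in the ring does move the number when it changes.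

Compound 4 `Cc1cccc2sc(NC(=O)CCN3CCN(c4ncccn4)CC3)nc12` is not yet measured. It differs from compound 3 by pyrimidin-2-yl in place of 2-(diisopropylamino)ethyl on an amine nitrogen in a ring. No measured step swaps a chain for an aromatic ring at this position, so the three steps shown give only indirect guidance; they indicate that this position tolerates the tert-butyl and the 2-(diisopropylamino)ethyl groups alike and punishes the 2-(dimethylamino)ethyl group. From this, compound 4 is expected to sit near compound 3 with wide uncertainty, a step of a 2.5-fold higher number from compound 3 to compound 4 (0.39 log units; beyond the scatter), and its estimated value in this assay is 300 nM, from 80 nM to 1500 nM.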

Compound 4, inhibition constant: > 1000 nM
Compound 4 ended at the assay's limit; the forecaster's own chance of this, stated with the estimate: 25%; at least 3.3-fold (0.52 log units) between middle value and limit.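

In this assay, pyrimidin-2-yl is the first aromatic ring shown on this amine nitrogen in a ring, and it does not keep the binding seen with the two groups tolerated there: an at least 8.2-fold higher number from compound 3 to compound 4 (0.91 log units; beyond the scatter), and an at least 5.0-fold higher number from compound 1 to compound 4 (0.69 log units; beyond the scatter). Weak binding at this position therefore no longer belongs to 2-(dimethylamino)ethyl alone, and a large group is not enough to keep it, since the ring enters with fewer heavy atoms than the chain that leaves yet differs from tert-butyl too. The value of compound 4 is a limit and not a number, and its step to compound 2 cannot be read: the limit of > 1000 nM in this assay, at which 2 of the 4 values shown sit.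

From the compounds shown here alone, whether the loss belongs to the aromatic ring as such or to its ring nitrogens stays open, and a phenyl on the same nitrogen would speak to that. Also open, going by these compounds, is whether a 2-(piperidin-1-yl)ethyl chain would bind like the 2-(diisopropylamino)ethyl chain of compound 3.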